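Replacing the thiazole of compound 1 with a nitrobenzothiazole

This account rests on a few compounds, and the source may have more. Where it says the series, first, only, none or still open, it means among the compounds named here.

compound 1 `O=C(CNC(=O)c1nn(-c2ccccc2)c(=O)c2ccccc12)Nc1nccs1` — > 25000 nM
compound 2 `COc1ccc(-n2c(SCC(=O)Nc3nc4ccc(Cl)cc4s3)nc3c(c2=O)SCC3)cc1` — 35 nM
compound 3 `O=C(CSc1nc2c(c(=O)n1-c1ccccc1)SCC2)Nc1ncc(-c2ccco2)cn1` — 3.5 nM

Of the compounds shown here, three have been measured in an assay on L cells for inhibition of Protein-serine O-palmitoleoyltransferase porcupine (Mus musculus), read by reporter gene assay, with a stated time of 24 h; a higher number here means that more compound is needed for the effect, a lower number that less compound is needed. Compound 1 gives only a limit of the assay, > 25000 nM, so it stands at the limit of > 25000 nM in this assay, at which 1 of the 3 values shown sits, with no number of its own. Compound 2 gives 35 nM and compound 3 gives 3.5 nM; both are built on a different core from compound 1, so their values offer no direct comparison for the step considered here. Compound 4 `O=C(CNC(=O)c1nn(-c2ccccc2)c(=O)c2ccccc12)Nc1nc2ccc([N+](=O)[O-])cc2s1` differs from compound 1 in one place: 6-nitro-1,3-benzothiazol-2-yl in place of 1,3-thiazol-2-yl on an amide-type nitrogen. For the measured compounds named here, no measured step joins two compounds that differ in only this way. The step from compound 1 to compound 4 is estimated as an at least 1.6-fold lower number from compound 1 to compound 4 (0.22 log units; that floor lies within the scatter), a modest gain at best. Compound 4 is expected to give 15000 nM, within 3000 nM to 50000 nM.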

Compound 4, half-maximal effective concentration: 240 nM
The estimate for compound 4 lay 63-fold (1.80 log units) above the measured number, outside the stated range (below it).
By their numbers in this assay, from the lowest: compound 3; then compound 2; then compound 4. At a limit, above all of these: compound 1.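

On the amide-type nitrogen, 6-nitro-1,3-benzothiazol-2-yl in place of 1,3-thiazol-2-yl gives an at least 100-fold lower number from compound 1 to compound 4 (2.01 log units; beyond the scatter) in this assay. For the compounds shown here, this shows that the group at this position has a large bearing on the number for this core, which the earlier compounds, all differing in more than one place, could not show. The step is only a floor, since compound 1 stands at a limit of the assay: the limit of > 25000 nM in this assay, at which 1 of the 4 values shown sits.

The change brings in the carbon-only six-membered aromatic ring and the nitro group together, and the compounds shown do not separate the two. As far as these compounds go, whether an amine or a methoxy group in place of the nitro would keep the number also remains open.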